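Urea to Chlorinated Amide: Expected Growth Inhibition of Compound 3

This account rests on a few compounds, and the source may have more. Where it says the series, first, only, none or still open, it means among the compounds named here.

Compound 1 `COc1cc(-c2nn(-c3cccc(NC(=O)c4cccc(C(F)(F)F)c4)c3)cc2-c2ccncc2)ccc1Cl`: 687 nM
Compound 2 `COc1cc(-c2nn(-c3cccc(NC(=O)Nc4cccc(C(F)(F)F)c4)c3)cc2-c2ccncc2)ccc1Cl`: 958 nM

In a functional assay on A498 cells (Homo sapiens) for inhibition, read by sulforhodamine B assay, with a stated time of 48 h (a lower number here means a stronger inhibitor of growth, a higher number a weaker inhibitor of growth), compound 1 gives 687 nM, while compound 2 gives 958 nM, the higher of the two numbers; the step of a 1.4-fold higher number from compound 1 to compound 2 (0.14 log units; within the scatter) is within the scatter. Compound 3 `COc1cc(-c2nn(-c3cccc(NC(=O)c4ccc(Cl)c(C(F)(F)F)c4)c3)cc2-c2ccncc2)ccc1Cl` differs from compound 2 by 4-chloro-3-(trifluoromethyl)phenyl in place of (3-(trifluoromethyl)phenyl)amino on a carbonyl carbon. Within the data shown here, only one measured step, a 1.4-fold higher number from compound 1 to compound 2 (0.14 log units; within the scatter), bears on this position, and it stayed within the scatter, so no movement beyond the scatter is expected. Compound 3 is therefore expected to give 600 nM, within 250 nM to 1500 nM, a step of a 1.6-fold lower number from compound 2 to compound 3 (0.20 log units; within the scatter).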

Compound 3, concentration for 50% growth inhibition: 2700 nM
Beside the measured number, compound 3's estimate is 4.5-fold (0.65 log units) below it; measured number outside the range, above it.
By their numbers in this assay, from the lowest: compounds 1 and 2 (each within the scatter of the next); then compound 3.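

In this assay, chloro in place of hydrogen on an aromatic carbon gives a 3.9-fold higher number from compound 1 to compound 3 (0.59 log units; beyond the scatter) and so moves the number beyond the scatter, which the change of linking group between compound 1 and compound 2 did not do. The swap of (3-(trifluoromethyl)phenyl)amino for 4-chloro-3-(trifluoromethyl)phenyl on the carbonyl carbon likewise gives a 2.8-fold higher number from compound 2 to compound 3 (0.45 log units; beyond the scatter) and weakens growth inhibition. No evidence is available to account for this weakening. As far as these compounds go, it remains open whether a fluoro, methyl or methoxy group in place of this chloro would weaken growth inhibition as well, and whether the chloro would have the same effect on the urea of compound 2.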